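This account rests on a few compounds, and the source may have more. Where it says the series, first, only, none or still open, it means among the compounds named here.

In a functional assay on A549 cells (Homo sapiens) for cytotoxicity, read by XTT assay, with a stated time of 72 h (on this read-out lower numbers stand for stronger inhibition and higher numbers for weaker inhibition), compound 3 `C=C1CC[C@H]2C(C)(C)CCC[C@]2(C)[C@H]1CC/C(C)=C/COc1cc(O)c2c(=O)c(OC/C=C(\C)CC[C@H]3C(=C)CC[C@H]4C(C)(C)CCC[C@]34C)c(-c3ccc(O)cc3)oc2c1` gives only a limit, > 100000 nM. Compound 1 `C=C1CC[C@H]2C(C)(C)CCC[C@]2(C)[C@H]1CC/C(C)=C/COc1cc(O)c2c(=O)c(OC/C=C(\C)CC[C@H]3C(=C)CC[C@H]4C(C)(C)CCC[C@]34C)c(-c3ccc(OC)cc3)oc2c1` differs from compound 3 by methyl in place of hydrogen on an oxygen on an aromatic ring. Compound 1 also stops at a limit, > 100000 nM. The step that the two limits leave unreadable from compound 3 to compound 1 therefore cannot be read, because both values sit at the limit of > 100000 nM in this assay, at which 2 of the 3 values shown sit. Compound 2 `C=C1CC[C@H]2C(C)(C)CCC[C@]2(C)[C@H]1CC/C(C)=C/COc1c(-c2ccc(O)cc2)oc2cc(O)cc(O)c2c1=O` has a core that differs from that of compound 3 in a way not broken down here. Among the measured compounds shown here, compound 2 gives 26000 nM in this assay, the only plain number of the three. Compound 4 `C=C1CC[C@H]2C(C)(C)CCC[C@]2(C)[C@H]1CC/C(C)=C/COc1c(-c2ccc(OC)cc2)oc2cc(O)cc(O)c2c1=O` is reached from compound 2 by the same change, (methyl in place of hydrogen on an oxygen on an aromatic ring), at a place described in the same words as before. Compound 2 gives 26000 nM, and with the earlier step unreadable the step expected from that value is a 1.2-fold higher number from compound 2 to compound 4 (0.06 log units; within the scatter). Compound 4 is accordingly estimated at 30000 nM, between 9000 nM and 100000 nM.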

Compound 4, half-maximal inhibitory concentration: 30000 nM
Compound 4: middle estimate and measured number agree at the digits printed; the measured number falls inside the stated range.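

In this assay, going from hydroxy to methoxy on the core of compound 2 gives a 1.2-fold higher number from compound 2 to compound 4 (0.06 log units; within the scatter), so on this core the two compounds cannot be told apart. The same change on the core of compound 3 cannot be read, since compound 3 and compound 1 both stop at a limit of the assay: the limit of > 100000 nM in this assay, at which 2 of the 4 values shown sit.

The change can therefore be read on one core only, and these compounds do not show whether the result carries over to another core. They leave open how a longer chain on that oxygen, such as ethyl, would read on the core of compound 2. They also leave open how an amine or a carboxylic acid in place of the hydroxy would read there.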